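Aryl ketone amide series: methyl removal on the aromatic ring

The compounds below may be only part of what the source reports. "The series", "measured", "known", "first", "only" and "open" are said of these compounds alone.

Of the compounds shown here, two of the shared core have been tested. Compound 1 is `COc1ccc(C(=O)CCC(=O)NCCCO)cc1` and compound 2 is `Cc1ccc(C(=O)CCC(=O)NCCCO)c(C)c1`. In a functional assay on the whole organism with Mus musculus as the target, in the maximal electroshock model (on this read-out higher numbers stand for an effect only at larger amounts of compound and lower numbers for an effect already at smaller amounts), compound 2 gives only a limit, > 150 mg/kg. Compound 1 also gives only a limit in this assay, > 600 mg/kg. Neither result is a number, so for compound 2 all that can be said is that one of the two values sits at the limit of > 150 mg/kg in this assay, at which 1 of the 2 values shown sits, and the other at the limit of > 600 mg/kg in this assay, at which 1 of the 2 values shown sits.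

Compound 3 is `Cc1ccc(C(=O)CCC(=O)NCCCO)cc1`. It differs from compound 2 by hydrogen in place of methyl on an aromatic carbon. With both measured values standing at limits, nothing sizes or directs this step; the step expected in this assay is a step that the limit leaves unreadable from compound 2 to compound 3, no change beyond the usual scatter. Compound 3 is expected to give 300 mg/kg in this assay, within a range of 100 mg/kg to 1000 mg/kg, and most probably to be reported once more as a limit rather than a number.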

Compound 3, dose for half-maximal effect: > 300 mg/kg
Compound 3: no number, only a limit; the forecaster's own chance of this, stated with the estimate: 70%; the middle value sits exactly at the limit.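

No step can be read between compound 3 and compound 2 or compound 1: in this assay all three give only limits, not numbers. Open remains what dose each compound needs in this assay, and whether methyl, methoxy or hydrogen on the aromatic carbon makes any difference.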